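Swapping hydroxymethyl for dimethylamino at a solubility limit

This account rests on a few compounds, and the source may have more. Where it says the series, first, only, none or still open, it means among the compounds named here.

Compound 1 (`Cc1noc(-c2nc(C)c3c(c2N)C(=O)N(Cc2ccc(OC(F)(F)F)cc2)C3=O)n1`), compound 2 (`Cc1noc(-c2nc(C)c3c(c2N)C(=O)N(Cc2ccc(SC(F)(F)F)cc2)C3=O)n1`) and compound 3 (`Cc1noc(-c2nc(C)c3c(c2N)C(=O)N(Cc2ccc(CO)cc2)C3=O)n1`) share a core and differ in a single group. All three were tested in a physicochemical assay for solubility, using the shake flask method, in simulated intestinal fluid, measured as kinetic solubility, with a stated time of 2 h, at 25 degrees C, at pH 6.5; a lower number here means a less soluble compound, a higher number a more soluble compound. Compound 1 gives < 5000 nM, which is a limit of the assay and not a number. Compound 2 gives < 5000 nM, which is also a limit. Compound 3 gives < 5000 nM, again a limit, so it has no exact place among the three.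

Compound 4 (`Cc1noc(-c2nc(C)c3c(c2N)C(=O)N(Cc2ccc(N(C)C)cc2)C3=O)n1`) carries dimethylamino in place of hydroxymethyl on an aromatic carbon.

The measured steps closest to this change are a step that the two limits leave unreadable from compound 1 to compound 3 and a step that the two limits leave unreadable from compound 2 to compound 3, and the remaining one is a step that the two limits leave unreadable from compound 1 to compound 2. None of them has a readable size, so they point in no direction. Among the compounds with values here, the only guide is the limit of < 5000 nM in this assay, at which 3 of the 3 values shown sit. No step beyond the usual scatter is therefore expected in this assay, and the assay will probably report a limit again. The estimate amounts to a step that the limit leaves unreadable from compound 3 to compound 4. For compound 4 the estimated value is 3000 nM, with an expected range from 1000 nM to 6000 nM.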

Compound 4, solubility: 7400 nM
Compound 4: the middle estimate sits 2.5-fold (0.39 log units) below what was measured, outside the stated range (above it).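

Within the data shown here, with dimethylamino at this position, para to a large group, compound 4 gives an exact number in this assay, 7400 nM, which none of the earlier compounds provided. This allows three steps to be given a floor: an at least 1.4-fold higher number from compound 3 to compound 4 (0.17 log units; that floor lies within the scatter), an at least 1.4-fold higher number from compound 2 to compound 4 (0.17 log units; that floor lies within the scatter) and an at least 1.4-fold higher number from compound 1 to compound 4 (0.17 log units; that floor lies within the scatter). Each floor lies within the usual scatter, and the true size of each step stays unknown because the other three values are limits, as are the steps among those compounds: the limit of < 5000 nM in this assay, at which 3 of the 4 values shown sit.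

The compounds shown leave open whether the exact number belongs to dimethylamino alone or would also appear with another amine, such as a morpholine or a piperazine, at this position. They also leave open what a carboxylic acid or a longer chain ending in an amine would give here.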